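Bromine for Difluorophenyl on an Aminothiophene-Type Ketone Scaffold

The source may hold more compounds than are shown below. What is called first, only, known or untested is meant among the compounds shown, and "the series" means these compounds.

Compound 1, `CC(C)(C)Cc1c(-c2ccc(F)cc2F)sc(N)c1C(=O)c1ccc(Cl)cc1`: 1%
Compound 2, `CC(C)(C)Cc1csc(N)c1C(=O)c1ccc(Cl)c(Cl)c1`: 1%

In an assay on CHO cells for displacement of a labelled ligand from adenosine receptor A1 (Homo sapiens), read by scintillation counting, tested at 10 uM (a lower number here means less inhibition, a higher number more inhibition at the concentration tested (going by the name of the read-out)), compound 1 gives 1% and compound 2 gives 1%. The two stand level at the digits recorded, and compound 2 is the nearest neighbour of compound 1, with no difference between them beyond the scatter. Compound 2 differs from compound 1 in more than one place. Among the measured compounds shown here, no single counted step joins them; their values show only that both sit at the bottom of the inhibition scale.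

Compound 3, `CC(C)(C)Cc1c(Br)sc(N)c1C(=O)c1ccc(Cl)cc1`, is the untested member. It arises from compound 1 by a single exchange: bromo in place of 2,4-difluorophenyl on an aromatic carbon

Both measured compounds show next to no displacement, and the exchange in compound 3 removes the aryl group without introducing anything that the measured data tie to a gain. No step beyond the scatter is therefore expected: the step from compound 1 to compound 3 is estimated at a number 2 percentage points higher from compound 1 to compound 3 (within the scatter), which amounts to no change within the usual spread. Compound 3 is expected to give 3%, with a range from -8% to 15%.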

Compound 3, a percentage reported as inhibition, at one concentration (the size of the read-out at that concentration, not a potency): 1%
The estimate for compound 3 lay 2 percentage points above the measured number; low and high end bracket the measured number.
By their numbers in this assay, from the lowest: compounds 1, 2 and 3 (each within the scatter of the next).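

In this assay, bromo in place of 2,4-difluorophenyl, on the aromatic carbon next to the ring sulfur, gives no change at the digits printed from compound 1 to compound 3 (within the scatter). Among the compounds shown here, this is the first step that changes this position alone, and it shows that losing the six-membered aromatic ring of carbon only from this carbon leaves the reading where it was, with compound 3 at 1% and still at the bottom of the inhibition scale. Since both ends of the step lie there, it cannot show whether the group on this carbon would matter in a compound with measurable inhibition, and nothing available speaks to why the reading stays flat.

On these data alone, whether an amine, a carboxylic acid or a longer chain on this carbon would lift the reading in this assay remains open. So does the effect of exchanging the neopentyl group or the (4-chlorophenyl)carbonyl group on the ring atoms that bear them, and of testing above or below the single concentration used here, since one reading at one concentration gives no potency.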